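A few compounds are considered here, and "the series" means these few. Any claim that something is new, unique, unknown or untested is made for them only; others in the source may bear on it.

In a functional assay on V79 cells (Cricetulus griseus) for cytotoxicity, read by colony formation (a higher number here means a weaker inhibitor, a lower number a stronger inhibitor), compound 1 `COc1c(N2CCC(N)C2)c(F)cc2c(=O)c(C(=O)O)cn(C3CC3)c12` gives 45 ug/mL; 44 ug/mL; 45 ug/mL (3 entries) and compound 2 `COc1c(N2CCC(C)(CN)C2)c(F)cc2c(=O)c(C(=O)O)cn(C3CC3)c12` gives 38 ug/mL, two results within the scatter of each other. Compound 3 `CNCC1(C)CCN(c2c(F)cc3c(=O)c(C(=O)O)cn(C4CC4)c3c2F)C1` gives 8 ug/mL. This is the lowest number of the set, and the gap to its nearest neighbour, compound 2, lies beyond the scatter.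

Compound 4 `CNCC1(C)CCN(c2c(F)cc3c(=O)c(C(=O)O)cn(C4CC4)c3c2OC)C1` has not yet been measured. It is compound 3 with methoxy in place of fluoro on an aromatic carbon. Within the data shown here, no two measured compounds differ in one place only, so the size of this step can only be judged loosely. Methoxy already stands in that place in compound 1, at 45 ug/mL; 44 ug/mL; 45 ug/mL (3 entries), and in compound 2, at 38 ug/mL. Since compound 4 keeps the remainder of compound 3, at 8 ug/mL, only part of that gap is expected to open in this assay.

The expected change is a rise beyond the scatter a 2.8-fold higher number from compound 3 to compound 4 (0.44 log units; beyond the scatter), toward a weaker inhibitor. Compound 4 is estimated at 22 ug/mL, with an expected range of 10 ug/mL to 45 ug/mL.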

Compound 4, half-maximal inhibitory concentration: 120 ug/mL
Compound 4: the middle estimate sits 5.5-fold (0.74 log units) below what was measured; the whole stated range lies below it.
By their numbers in this assay, from the lowest: compound 3; then compound 2; then compound 4.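

In this assay, methoxy in place of fluoro on the aromatic carbon ortho to the 3-methyl-3-((methylamino)methyl)pyrrolidin-1-yl group can now be read directly, and it gives a 15-fold higher number from compound 3 to compound 4 (1.18 log units; beyond the scatter), a large step toward a weaker inhibitor. Methyl in place of hydrogen on the amine nitrogen gives a 3.2-fold higher number from compound 2 to compound 4 (0.50 log units; beyond the scatter), a modest step in the same direction with methoxy held in place. The low number of compound 3 therefore goes with fluoro at this position and not with the methylated amine alone, and repeated readings of this assay agree closely: the several entries of compound 1 in this assay, 45 ug/mL; 44 ug/mL; 45 ug/mL (3 entries)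

The compounds shown leave open how methyl on the amine nitrogen acts when fluoro stands on the aromatic carbon. They also leave open how chloro, ethoxy or hydrogen on that carbon would read in this assay.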